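The source may hold more compounds than are shown below. What is called first, only, known or untested is meant among the compounds shown, and "the series" means these compounds.

Measured compounds:
- compound 1, `CCCOC(=O)C1=C(C)NC(=O)NC1c1ccsc1`: 6% in an assay on membranes from HeLa cells for displacement of a labelled ligand from adenosine receptor A3 (Homo sapiens), read by scintillation counting, with a stated time of 180 min, tested at 1 uM; a lower number here means less inhibition, a higher number more inhibition at the concentration tested (going by the name of the read-out)
- compound 2, `CC1=C(C(=O)OC2CCC2)C(c2ccsc2)NC(=O)N1`: 3% in this assay

Compound 2 stands lowest of the two numbers, but its nearest neighbour, compound 1, lies within the scatter of it, so no order between the two can be read; both show little inhibition in this assay. Within the data shown here, the only measured step, a number 3 percentage points lower from compound 1 to compound 2 (within the scatter), concerns a change at the same place as the one now in question, cyclobutyl in place of propyl on an oxygen next to a carbonyl group, and it was within the scatter.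

Compound 3, `CC1=C(C(=O)OCC2CCC2)C(c2ccsc2)NC(=O)N1`, differs from compound 2 by cyclobutylmethyl in place of cyclobutyl on an oxygen next to a carbonyl group. Among the measured compounds shown here, the one step that bears on this, a number 3 percentage points lower from compound 1 to compound 2 (within the scatter), gives no sign that a change at this place moves the read-out in this assay. The expected step of a number 2 percentage points higher from compound 2 to compound 3 (within the scatter) is therefore none beyond the scatter, with compound 3 expected to remain near the low level of compound 2. The estimate for compound 3 in this assay is 5%, with a range from -5% to 15%.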

Compound 3, a percentage reported as inhibition, at one concentration (the size of the read-out at that concentration, not a potency): 2%
The estimate for compound 3 lay 3 percentage points above the measured number, and the stated range covers the measured number.
By their numbers in this assay, from the lowest: compounds 3, 2 and 1 (each within the scatter of the next).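

With cyclobutylmethyl in place of cyclobutyl on an oxygen next to a carbonyl group, this assay shows a number 1 percentage points lower from compound 2 to compound 3 (within the scatter): moving from 4 to 5 heavy atoms while keeping the four-membered ring does not separate the two compounds. The second new comparison, cyclobutyl in place of ethyl on a saturated chain carbon bound to an oxygen next to a carbonyl group, gives a number 4 percentage points lower from compound 1 to compound 3 (within the scatter), so the propyl, cyclobutyl and cyclobutylmethyl groups now form a set of three at this place with no step beyond the scatter. Nothing at hand offers an explanation for this lack of separation.

From the compounds shown here alone, all three groups are carbon-only, so it remains open whether a longer chain, a phenyl ring, an amine or a carboxylic acid at this place would move the read-out beyond the scatter. Since each compound is described at a single concentration, the notes also leave open how these compounds would compare at higher concentrations or in a measure of potency.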